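Amino for hydrogen on the dichloro-free core of compound 2

This account rests on a few compounds, and the source may have more. Where it says the series, first, only, none or still open, it means among the compounds named here.

The three measured compounds share one fused core. Compound 1 `ClCc1ccccc1Cn1cnc2c(Cl)nc(Cl)nc21` carries two chloro groups on it; compound 2 `ClCc1ccccc1Cn1cnc2c(Cl)ncnc21` carries one; compound 3 `ClCc1cccc(Cn2cnc3c(Cl)ncnc32)c1` is the isomer of compound 2 with the benzyl attachment moved. In a functional assay on UACC-62 cells (Homo sapiens) for cytotoxicity, read by sulforhodamine B assay, with a stated time of 48 h (a lower number here means a stronger inhibitor of growth, a higher number a weaker inhibitor of growth), compound 1 gives 2630 nM, compound 2 gives 6600 nM, and compound 3 gives 3380 nM. Among the measured compounds shown here, compound 2 therefore holds the highest number of the three, though its gap to compound 3 lies within the scatter; only compound 1 sits clearly lower, the single one-point step in this assay being a 2.5-fold higher number from compound 1 to compound 2 (0.40 log units; beyond the scatter).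

Compound 4 `Nc1nc(Cl)c2ncn(Cc3ccccc3CCl)c2n1` differs from compound 2 by amino in place of hydrogen on an aromatic carbon. For the measured compounds named here, no measured step involves an amino group, so the only bearing comes from the step from compound 1 to compound 2, which touched the same position and showed that removing a substituent there raised the number modestly. Returning a substituent in that place could plausibly reverse part of that shift, but nothing measured fixes its size, and a result within the scatter is equally consistent with the data.

For compound 4 in this assay a modest decrease is expected, a 1.9-fold lower number from compound 2 to compound 4 (0.28 log units; within the scatter), giving an estimate of 3500 nM with a range from 1200 nM to 10000 nM.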

Compound 4, concentration for total growth inhibition: 4370 nM
Estimate against measurement, compound 4: 1.2-fold (0.10 log units) below; the range from low to high includes it.
By their numbers in this assay, from the lowest: compounds 1, 3, 4 and 2 (each within the scatter of the next, the first and the last beyond it).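

In this assay, amino in place of hydrogen on the aromatic carbon between two ring nitrogen atoms gives a 1.5-fold lower number from compound 2 to compound 4 (0.18 log units; within the scatter), and amino in place of chloro on that same carbon gives a 1.7-fold higher number from compound 1 to compound 4 (0.22 log units; within the scatter). Among the compounds shown here, the earlier compounds offered only one readable step here, a 2.5-fold higher number from compound 1 to compound 2 (0.40 log units; beyond the scatter), which set chloro and hydrogen apart; amino now stands within the scatter of both, so this third substituent cannot be told apart from either, even though those two differ from each other. No measurement in hand bears on the reason for this reading.

Open, on these data alone, is whether any other group on this carbon, such as methoxy, methylamino or fluoro, would separate clearly from amino, chloro and hydrogen, or whether the whole span at this position stays as narrow as these three substituents suggest. Also open is whether amino reads the same way with the benzyl attachment of compound 3, since the amino compound shown carries only the attachment of compound 2.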